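The source may report more compounds than this note shows. Statements on the series, on what has been measured and on what is new or still open speak of the compounds shown alone.

Compound 1 `COc1ccc(CNC(=O)/C(C#N)=C/c2ccco2)cc1` gives 32000 nM in a functional assay on NCI-H460 cells (Homo sapiens) for inhibition, read by MTT assay, with a stated time of 72 h; on this read-out higher numbers stand for weaker inhibition of growth and lower numbers for stronger inhibition of growth. Compound 2 `COc1ccc(CNC(=O)/C(C#N)=C/c2ccc(Cl)o2)cc1` carries chloro in place of hydrogen on an aromatic carbon and gives 15000 nM in this assay; this change amounts to a 2.1-fold lower number from compound 1 to compound 2 (0.33 log units; beyond the scatter). Compound 3 `N#C/C(=C\c1ccccc1)C(=O)NCc1ccc(Cl)c(Cl)c1` rests on a different core, and the difference between the two cores is not broken down here. In this assay compound 3 gives 61000 nM.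

Compound 4 `N#C/C(=C\c1ccc(Cl)cc1)C(=O)NCc1ccc(Cl)c(Cl)c1` is not yet measured and differs from compound 3 by chloro in place of hydrogen on an aromatic carbon. This is the same kind of change as that from compound 1 to compound 2, not the same: there the place was on a five-membered aromatic ring with 1 oxygen, next to the ring oxygen, two ring bonds from the ring atom that bears a large group; here it is on a six-membered aromatic ring of carbon only, para to a large group. Set beside the earlier step, compound 4 is expected to show a 2.0-fold lower number from compound 3 to compound 4 (0.31 log units; beyond the scatter), a modest drop of about the same size. That expectation rests on one precedent only, a 2.1-fold lower number from compound 1 to compound 2 (0.33 log units; beyond the scatter), made on a different core. For compound 4 in this assay the estimate is 30000 nM, expected between 12000 nM and 80000 nM.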

Compound 4, concentration for 50% growth inhibition: 33000 nM
Compound 4: the middle estimate sits 1.1-fold (0.04 log units) below what was measured, within the range that was stated.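

Chloro in place of hydrogen on an aromatic carbon gives, in this assay, a 1.8-fold lower number from compound 3 to compound 4 (0.27 log units; within the scatter). Set beside the step on the core of compound 1, this step shows that the change carries over between these two cores with no difference in size that can be told apart: the same change on two cores in this assay, a 2.1-fold lower number (0.33 log units; beyond the scatter) from compound 1 to compound 2 and a 1.8-fold lower number (0.27 log units; within the scatter) from compound 3 to compound 4, 1.2-fold (0.06 log units) apart, within the scatter of two such steps

This rests on a single pair per core, with the chloro on a different ring in each, and the step on the core of compound 3 alone lies within the scatter, so it neither establishes a gain in growth inhibition on that core nor predicts the step on any further core.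

Open, from the compounds shown here alone, is whether fluoro, an amine or a carboxylic acid in the same place, para to a large group, would move the number in this assay at all.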